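The source may report more compounds than this note shows. Statements on the series, on what has been measured and on what is new or still open speak of the compounds shown alone.

Working notes on the series. Compound 1 `CNCc1ccc2c(c1)nc(Cn1c(=O)n(C(C)C)c3ccccc31)n2CCC(C)C` gives 1480 nM in an ADME assay on HEp-2 cells (Homo sapiens) for cytotoxicity; a higher number here means that more compound is tolerated, a lower number that less compound is tolerated. Compound 2 `CC(C)CCn1c(Cn2c(=O)n(C(C)C)c3ccccc32)nc2cc(CN(C)C)ccc21` differs from compound 1 by methyl in place of hydrogen on an amine nitrogen, and in this assay compound 2 gives 5650 nM, so the step is a 3.8-fold higher number from compound 1 to compound 2 (0.58 log units; beyond the scatter). Compound 3 `CNCc1ccc2nc(Cn3c(=O)n(C(C)C)c4ccccc43)n(CCC(C)C)c2c1` has the same atoms as compound 1 joined differently; the difference between the two cores is not broken down here. In this assay compound 3 gives 4810 nM. Going by the values given here, compound 4 `CC(C)CCn1c(Cn2c(=O)n(C(C)C)c3ccccc32)nc2ccc(CN(C)C)cc21` is not yet measured; it differs from compound 3 by methyl in place of hydrogen on an amine nitrogen, the same change at the same place as the one from compound 1 to compound 2. Among the compounds with values here, for compound 4 a step of a 2.9-fold higher number from compound 3 to compound 4 (0.46 log units; beyond the scatter) is expected, set beside the single earlier step of a 3.8-fold higher number from compound 1 to compound 2 (0.58 log units; beyond the scatter) on which this expectation rests. The estimate for compound 4 is 14000 nM, with an expected range from 6000 nM to 35000 nM.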

Compound 4, half-maximal cytotoxic concentration: 26700 nM
For compound 4 the middle estimate is 1.9-fold (0.28 log units) below the measured one; the measured number falls inside the stated range.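

In this assay the new step is a 5.6-fold higher number from compound 3 to compound 4 (0.74 log units; beyond the scatter), so methyl in place of hydrogen on the amine nitrogen raises the number on the second core as well. The two steps run the same way and do not differ in size beyond the scatter: the same change on two cores in this assay, a 3.8-fold higher number (0.58 log units; beyond the scatter) from compound 1 to compound 2 and a 5.6-fold higher number (0.74 log units; beyond the scatter) from compound 3 to compound 4, 1.5-fold (0.16 log units) apart, within the scatter of two such steps

Within this pair of cores, the step from (methylamino)methyl to (dimethylamino)methyl carried from one to the other, but two steps do not show why the number rises or that it would do so on any further core.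

The compounds shown leave open whether a primary amine, or ethyl in place of methyl on the nitrogen, would continue the same trend. Going by these compounds, how this change reads outside this assay also remains open.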